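Pyrazolone series: methyl removal on the pyrazole amine

The compounds below may be only part of what the source reports. "The series", "measured", "known", "first", "only" and "open" are said of these compounds alone.

Measured compounds:
compound 1, `Cc1cc(N/C=C2\C(=O)NN=C2c2ccccc2)n[nH]1`, 96100 nM
compound 2, `O=C1NN=C(c2ccccc2)/C1=C/Nc1cc[nH]n1`, 95300 nM
compound 3, `Cc1cc(N/C=C2\C(=O)N(c3ccccc3)N=C2c2ccccc2)n[nH]1`, 9980 nM

All three were run in a functional assay on MDA-MB-361 cells (Homo sapiens) for antiproliferative activity, read by MTT assay, with a stated time of 72 h; on this read-out higher numbers stand for weaker inhibition and lower numbers for stronger inhibition. Compound 1 and compound 2 differ only by hydrogen in place of methyl on an aromatic carbon. The step of a 1.0-fold lower number from compound 1 to compound 2 (0.00 log units; within the scatter) shows that this change left the read-out essentially unchanged between these two compounds. Compound 3 differs from compound 1 by phenyl in place of hydrogen on an amide-type nitrogen in a ring, and the step of a 9.6-fold lower number from compound 1 to compound 3 (0.98 log units; beyond the scatter) is the only movement beyond the scatter among the three measured compounds, so compound 3 stands apart from the other two on this assay.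

Compound 4, `O=C1/C(=C\Nc2cc[nH]n2)C(c2ccccc2)=NN1c1ccccc1`, is not yet measured. It stands to compound 3 as compound 2 stands to compound 1: the difference hydrogen in place of methyl on an aromatic carbon is the same change already seen once, and the place described for it is the same word for word as for the earlier pair, while the two cores differ by phenyl in place of hydrogen on an amide-type nitrogen in a ring. Because the earlier occurrence of this change gave a 1.0-fold lower number from compound 1 to compound 2 (0.00 log units; within the scatter), the step from compound 3 to compound 4 is expected to be of similar size, a 1.0-fold higher number from compound 3 to compound 4 (0.00 log units; within the scatter), and to stay within the scatter. This rests on a single precedent, so the range is kept wide. On that basis compound 4 is expected to give about 10000 nM in this assay, estimated to lie between 4500 nM and 22000 nM.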

Compound 4, half-maximal inhibitory concentration: 51000 nM
The estimate for compound 4 lay 5.1-fold (0.71 log units) below the measured number, outside the stated range (above it).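

In this assay, hydrogen in place of methyl does not carry over from one core to the other: the change from 5-methyl-1H-pyrazol-3-yl to 1H-pyrazol-3-yl gives a 5.1-fold higher number from compound 3 to compound 4 (0.71 log units; beyond the scatter), and the comparison with the core of compound 1 reads: the same change on two cores in this assay, a 1.0-fold lower number (0.00 log units; within the scatter) from compound 1 to compound 2 and a 5.1-fold higher number (0.71 log units; beyond the scatter) from compound 3 to compound 4, 5.2-fold (0.71 log units) apart, beyond the scatter of two such steps The same four compounds show the phenyl change depending on the pyrazole group, since phenyl in place of hydrogen on the amide-type nitrogen gives only a 1.9-fold lower number from compound 2 to compound 4 (0.27 log units; within the scatter) on the 1H-pyrazol-3-yl core, and the comparison reads: the same change on two cores in this assay, a 9.6-fold lower number (0.98 log units; beyond the scatter) from compound 1 to compound 3 and a 1.9-fold lower number (0.27 log units; within the scatter) from compound 2 to compound 4, 5.2-fold (0.71 log units) apart, beyond the scatter of two such steps These two gaps are one interaction seen from two sides, so the methyl and the phenyl cannot be scored as separate, additive contributions here, but one set of four compounds in one cell line does not show why they interact or whether the same holds elsewhere in the series.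

From the compounds shown here alone, it remains open whether an ethyl group or a chlorine atom on the same aromatic carbon would behave as the methyl does on the phenyl-bearing core. Going by these compounds, it is also open whether a benzyl group or a methyl group on the amide-type nitrogen would show the same dependence on the pyrazole group as phenyl.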